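Propyl to 2-nitrophenyl on the sulfonyl sulfur

A few compounds are considered here, and "the series" means these few. Any claim that something is new, unique, unknown or untested is made for them only; others in the source may bear on it.

Of the compounds shown here, three sharing one core have been read in a functional assay on HepG2 cells (Homo sapiens) for antiproliferative activity, read by MTT assay, with a stated time of 48 h; on this read-out higher numbers stand for weaker inhibition and lower numbers for stronger inhibition. Compound 1 (`Cc1ccc(S(=O)(=O)n2cc(/C=C/C(=O)c3ccncc3)c3ccccc32)cc1`) gives 44800 nM, compound 2 (`COc1ccc(S(=O)(=O)n2cc(/C=C/C(=O)c3ccncc3)c3ccccc32)cc1`) gives 26000 nM, and compound 3 (`CCCS(=O)(=O)n1cc(/C=C/C(=O)c2ccncc2)c2ccccc21`) gives 46200 nM. Compound 3 stands within the scatter of both others, and the three values do not separate.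

The step under consideration leads to compound 4 (`O=C(/C=C/c1cn(S(=O)(=O)c2ccccc2[N+](=O)[O-])c2ccccc12)c1ccncc1`), with 2-nitrophenyl in place of propyl on a sulfonyl sulfur.

Two measured steps exchange a substituted phenyl group and propyl at this same place. These are a 1.0-fold higher number from compound 1 to compound 3 (0.01 log units; within the scatter) and a 1.8-fold higher number from compound 2 to compound 3 (0.25 log units; within the scatter), and neither exceeds the scatter. The exchange of methoxy for methyl, a 1.7-fold lower number from compound 1 to compound 2 (0.24 log units; within the scatter), also stays within the scatter. Taken together, these steps give no sign that the group on the sulfonyl sulfur moves the read-out in this small set. Within the data shown here, no measured compound carries the 2-nitrophenyl group, however, and this leaves the estimate uncertain.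

No shift beyond the scatter is therefore expected in this assay. The expected step is a 1.4-fold lower number from compound 3 to compound 4 (0.16 log units; within the scatter). Compound 4 is estimated at 32000 nM, with an expected range from 13000 nM to 70000 nM.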

Compound 4, half-maximal inhibitory concentration: 31700 nM
Compound 4: the middle estimate sits 1.0-fold (0.00 log units) above what was measured; the range from low to high includes it.
By their numbers in this assay, from the lowest: compounds 2, 4, 1 and 3 (each within the scatter of the next).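

In this assay, 2-nitrophenyl on the sulfonyl sulfur gives a 1.5-fold lower number from compound 3 to compound 4 (0.16 log units; within the scatter) against propyl, a 1.2-fold higher number from compound 2 to compound 4 (0.09 log units; within the scatter) against 4-methoxyphenyl and a 1.4-fold lower number from compound 1 to compound 4 (0.15 log units; within the scatter) against 4-methylphenyl as the groups exchanged. The earlier compounds shown here covered only propyl and two phenyl groups with a small substituent, whereas this result extends the flat picture at this place, on a sulfonyl sulfur whose other neighbour is aromatic nitrogen, to a group with more heavy atoms and with hydrogen-bond acceptors that propyl lacks, and all four groups remain inseparable on this read-out. No measurement in hand accounts for this absence of separation.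

On these data alone, whether a carboxylic acid or an amine on the phenyl group, or a chain longer than propyl, would separate from these four groups at the sulfonyl sulfur remains open. As far as these compounds go, all four compounds keep the rest of the shared core unchanged, so the response of the read-out to an exchange anywhere else on that core also remains open.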